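This account rests on a few compounds, and the source may have more. Where it says the series, first, only, none or still open, it means among the compounds named here.

Values in a functional assay on MCF7 cells (Homo sapiens) for antiproliferative activity, with a stated time of 5 days; a higher number here means a weaker inhibitor, a lower number a stronger inhibitor:
- compound 1 `COc1ccc(-c2[nH]c3ccc(C)cc3c2C=O)cc1` gives 140 nM
- compound 2 `CCCCc1ccc2[nH]c(-c3ccc(OC)cc3)c(/C=N/NC(=O)c3ccc(OC)cc3)c2c1` gives 226 nM
- compound 3 `CCCCc1ccc2[nH]c(-c3ccc(C(F)(F)F)cc3)c(/C=N/NC(=O)c3ccc([N+](=O)[O-])cc3)c2c1` gives 6340 nM

Compound 2 lies within the usual scatter of compound 1, while compound 3 has a much higher number, well beyond the scatter from compound 2. The next compound to be tested is compound 4 `CCCCc1ccc2[nH]c(-c3ccc(OC)cc3)c(/C=N/NC(=O)c3cccnc3)c2c1`, which keeps the rest of compound 2 and carries pyridin-3-yl in place of 4-methoxyphenyl on a carbonyl carbon. Among the measured compounds shown here, no two measured compounds differ in only one place, so the series offers no direct precedent for this change, and its size cannot be read from the data. For the measured compounds named here, the only anchor is compound 2 at 226 nM. A modest rise in the number, meaning a somewhat weaker inhibitor, is expected, with an estimated 2.2-fold higher number from compound 2 to compound 4 (0.34 log units; beyond the scatter). Compound 4 is estimated at 500 nM in this assay, with an expected range from 150 nM to 2000 nM.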

Compound 4, half-maximal inhibitory concentration: 75 nM
Estimate against measurement, compound 4: 6.7-fold (0.82 log units) above; measured number below the stated range.
By their numbers in this assay, from the lowest: compounds 4, 1 and 2 (each within the scatter of the next, the first and the last beyond it); then compound 3.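

In this assay, among the compounds shown here, pyridin-3-yl in place of 4-methoxyphenyl on a carbonyl carbon gives a 3.0-fold lower number from compound 2 to compound 4 (0.48 log units; beyond the scatter), the only step that changes a single place. It shows that the group on this carbonyl carbon affects the read-out and that the 4-methoxyphenyl group is not required for activity at this level, since the pyridin-3-yl analogue, with fewer heavy atoms in this group, gives the lower number. No measured property bears on this result, so the step stands without an explanation.

Still open, on these data alone, is whether the step follows from the ring nitrogen of pyridin-3-yl or from the loss of the methoxy group, which an unsubstituted phenyl on the same carbonyl carbon would separate. Also open, as far as these compounds go, is whether the step holds with a longer chain in place of the butyl group.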